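The source may hold more compounds than are shown below. What is called first, only, known or untested is meant among the compounds shown, and "the series" means these compounds.

Measured in an ADME assay on PA-1 cells (Homo sapiens) for cytotoxicity, read by MTT assay, with a stated time of 72 h; on this read-out lower numbers stand for stronger inhibition and higher numbers for weaker inhibition:
Compound 1 `COc1ccc(C2=C(c3cc(OC)c(OC)c(OC)c3)CC(O)C2=O)cc1[N+](=O)[O-]`: > 100 ug/mL
Compound 2 `COc1ccc(C2=C(c3cc(OC)c(OC)c(OC)c3)C(=O)C(O)C2)cc1Cl`: > 100 ug/mL
Compound 3 `COc1ccc(C2=C(c3cc(OC)c(OC)c(OC)c3)C(=O)CC2O[SiH2]C(C)(C)C)cc1OC`: > 100 ug/mL

Each of these entries is a limit and not a number. Compound 3 shares (the limit of > 100 ug/mL in this assay, at which 3 of the 3 values shown sit). Compound 4 `COc1ccc(C2=C(c3cc(OC)c(OC)c(OC)c3)C(=O)CC2O[SiH2]C(C)(C)C)cc1O` differs from compound 3 by hydrogen in place of methyl on an oxygen on an aromatic ring, turning methoxy to hydroxy and 3,4-dimethoxyphenyl to 3-hydroxy-4-methoxyphenyl. Among the compounds with values here, the series offers no measured step to gauge this change. A shift towards stronger inhibition in this assay is expected, of uncertain size, and a reading at the same limit remains quite possible. The estimated change is an at least 2.5-fold lower number from compound 3 to compound 4 (0.39 log units; beyond the scatter). For compound 4 the expected value is 40 ug/mL, with an estimated range of 3 ug/mL to 100 ug/mL.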

Compound 4, half-maximal inhibitory concentration: 14 ug/mL
Compound 4: middle estimate off by 2.9-fold (0.46 log units), on the high side, and the stated range covers the measured number.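

In this assay, within the data shown here, the change from methoxy to hydroxy gives the only reading that is a number and not a limit, with an at least 7.1-fold lower number from compound 3 to compound 4 (0.85 log units; beyond the scatter). This shows that the 3-hydroxy-4-methoxyphenyl group can bring a measurable response where the 3,4-dimethoxyphenyl group of compound 3 stays at the limit. The true size of the step stays unknown, and it can be read only as a minimum: the limit of > 100 ug/mL in this assay, at which 3 of the 4 values shown sit.

Still open, from the compounds shown here alone, is whether the free hydroxy is needed, or whether an amine or an ethoxy group in its place would also give a number in this assay.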